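From 2,4-dimethoxyphenyl to 3,4-dimethoxyphenyl at the assay limit

A few compounds are considered here, and "the series" means these few. Any claim that something is new, unique, unknown or untested is made for them only; others in the source may bear on it.

In a functional assay on HeLa cells (Homo sapiens) for cytotoxicity, read by MTT assay, with a stated time of 48 h (on this read-out lower numbers stand for stronger inhibition and higher numbers for weaker inhibition), compound 1 `COc1ccc(/C=C/C(=O)/C=C/c2cc3ccccc3nc2Oc2ccccc2)cc1` gives > 10000 nM as a limit of the assay and not as a number. In this assay compound 2 `COc1ccc(/C=C/C(=O)/C=C/c2cc3ccccc3nc2Oc2ccccc2)c(OC)c1` gives > 10000 nM as a limit too. Compound 2 therefore stands at the limit of > 10000 nM in this assay, at which 2 of the 2 values shown sit, and has no number of its own.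

Compound 3 `COc1ccc(/C=C/C(=O)/C=C/c2cc3ccccc3nc2Oc2ccccc2)cc1OC` differs from compound 2 by 3,4-dimethoxyphenyl in place of 2,4-dimethoxyphenyl on a double-bonded chain carbon bound to a double-bonded chain carbon in a single change: 3,4-dimethoxyphenyl in place of 2,4-dimethoxyphenyl on a double-bonded chain carbon bound to a double-bonded chain carbon. Among the measured compounds shown here, the one measured step that bears on this change, methoxy in place of hydrogen on an aromatic carbon, is a step that the two limits leave unreadable from compound 1 to compound 2 and gives no size to carry forward. With no readable step to lean on, no change beyond the scatter can be argued in either direction in this assay for compound 3. The expected step is a step that the limit leaves unreadable from compound 2 to compound 3 on this estimate. Another reading at the limit is the likeliest outcome. Compound 3 is estimated at 12000 nM and expected to fall between 4000 nM and 30000 nM on this read-out.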

Compound 3, half-maximal inhibitory concentration: > 10000 nM
Compound 3 was reported as a limit (the forecaster's own chance of this, stated with the estimate: 70%); the middle value lies beyond the limit too.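

No new step can be read among compound 1, compound 2 and compound 3 in this assay, as each reading is a limit of the assay and not a number: the limit of > 10000 nM in this assay, at which 3 of the 3 values shown sit.

The compounds shown leave open whether 3,4-dimethoxyphenyl and 2,4-dimethoxyphenyl differ at all on this read-out, and what number any of the three would have.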